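A few compounds are considered here, and "the series" means these few. Any claim that something is new, unique, unknown or untested is made for them only; others in the source may bear on it.

Measured compounds:
- compound 1, `N=C(N)NCCC[C@H](NC(=O)CN(c1nc(Cl)nc2[nH]cnc12)C1CC1)C(=O)OCc1ccccc1`: 30.6%
- compound 2, `O=C(CN(c1nc(Cl)nc2[nH]cnc12)C1CC1)N[C@@H](CC(=O)OCc1ccccc1)C(=O)OCc1ccccc1`: 22.4%
- compound 3, `O=C(CN(c1nc(Cl)nc2[nH]cnc12)C1CC1)N[C@@H](CCC(=O)OCc1ccccc1)C(=O)OCc1ccccc1`: 53.7%

In a functional assay on the whole organism (Tail, strain ICR) with Mus musculus as the target, in the tail flick test, with a stated time of 60 min, at a dose of 25 umol/kg by the oral route (a lower number here means a weaker effect, a higher number a stronger effect of the compound at the dose given), compound 3 gives the highest of the three numbers, with a number 23.1 percentage points higher from compound 1 to compound 3 (beyond the scatter) and a number 31.3 percentage points higher from compound 2 to compound 3 (beyond the scatter) both beyond the scatter, while a number 8.2 percentage points lower from compound 1 to compound 2 (within the scatter) lies within it. Compound 4, `CSCC[C@H](NC(=O)CN(c1nc(Cl)nc2[nH]cnc12)C1CC1)C(=O)OCc1ccccc1`, has not yet been measured in this assay. The change is methylsulfanyl in place of benzyloxycarbonyl on a saturated chain carbon, three bonds along the chain from an amide-type nitrogen and a carbonyl carbon. The step that bears most on it is the one at the same place, a number 23.1 percentage points higher from compound 1 to compound 3 (beyond the scatter), which put the benzyloxycarbonyl group in and raised the read-out modestly; taking that group out again and leaving a small methylsulfanyl group is therefore expected to cost part of that gain. Within the data shown here, no measured step shows methylsulfanyl itself, so the estimate is uncertain. Compound 4 is expected to give about 32% in this assay, within a range of 15% to 50%, which would mean a number 21.7 percentage points lower from compound 3 to compound 4 (beyond the scatter) as the expected step.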

Compound 4, a percentage reported as activity, at one dose (the size of the read-out at that dose, not a potency): 30.8%
For compound 4 the middle estimate is 1.2 percentage points above the measured one; measured number inside the range.
By their numbers in this assay, from the lowest: compounds 2, 1 and 4 (each within the scatter of the next); then compound 3.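

In this assay, the step of a number 22.9 percentage points lower from compound 3 to compound 4 (beyond the scatter) shows that the higher read-out of compound 3 does not survive when benzyloxycarbonyl at this place gives way to methylsulfanyl. The new compound falls in with the other two, with a number 0.2 percentage points higher from compound 1 to compound 4 (within the scatter) and a number 8.4 percentage points higher from compound 2 to compound 4 (within the scatter), so among these compounds only the 2-(benzyloxycarbonyl)ethyl group stands apart, while compound 2, which carries benzyloxycarbonyl on a shorter chain, shows that the group alone does not bring the higher number. Nothing measured here explains this difference.

The compounds shown leave open whether a longer chain ending in benzyloxycarbonyl would hold or raise the read-out. They also leave open whether a carboxylic acid or an amine at the end of the chain would behave like methylsulfanyl.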